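Removing a Methoxy Group: What Activity to Expect

The source may report more compounds than this note shows. Statements on the series, on what has been measured and on what is new or still open speak of the compounds shown alone.

Of the compounds shown here, two have been measured in a functional assay on A-375 cells (Homo sapiens) for antiproliferative activity, read by MTT assay, with a stated time of 24 h, tested at 100 ug/mL; on this read-out higher numbers stand for a stronger effect at the one concentration tested and lower numbers for a weaker effect. Compound 1 `Cc1c(C(=O)Nc2ccc(-c3ccccc3)cc2)nc2ccccc2c1O` gives 52.3% in this assay. Compound 2 `COc1ccc2nc(C(=O)Nc3ccc(-c4ccccc4)cc3)c(C)c(C(=O)O)c2c1` gives 70.2%, the higher of the two numbers, with compound 1 standing beyond the scatter below it. Compound 3 `Cc1c(C(=O)Nc2ccc(-c3ccccc3)cc2)nc2ccccc2c1C(=O)O` has not yet been measured. It differs from compound 2 in one place: hydrogen in place of methoxy on an aromatic carbon. Among the compounds with values here, no measured pair shows what this change does, so the expected step is uncertain. The step expected is a number 5.2 percentage points lower from compound 2 to compound 3 (within the scatter), small and within the scatter. Compound 3 is therefore estimated at 65%, with a range from 50% to 80%.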

Compound 3, a percentage reported as inhibition, at one concentration (the size of the read-out at that concentration, not a potency): 50.3%
For compound 3 the middle estimate is 14.7 percentage points above the measured one; low and high end bracket the measured number.
By their numbers in this assay, from the lowest: compounds 3 and 1 (each within the scatter of the next); then compound 2.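

Taking the methoxy group off this aromatic carbon gives a number 19.9 percentage points lower from compound 2 to compound 3 (beyond the scatter) in this assay, so on this core the group at this position makes a real difference to the read-out. Carboxy in place of hydroxy gives a number 2 percentage points lower from compound 1 to compound 3 (within the scatter), so compound 1 and compound 3 cannot be told apart here. Nothing shown here gives a reason for either step.

The compounds shown leave open whether this difference is specific to methoxy or would also appear with an ethoxy group, an amine or a fluorine atom on the same carbon.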